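The compounds below may be only part of what the source reports. "The series", "measured", "known", "first", "only" and "open" are said of these compounds alone.

Measured compounds in an assay on HEK293 cells for inhibition of N-acylethanolamine-hydrolyzing acid amidase (Rattus norvegicus), read by LC-MS, with a stated time of 30 min; a lower number here means a stronger inhibitor, a higher number a weaker inhibitor:
compound 1, `O=C(CCCCCCc1cccc(F)c1)N1CCCC1`: 7300 nM
compound 2, `O=C(CCCCCCc1ccccc1Cl)N1CCCC1`: > 100000 nM, which is a limit of the assay and not a number (the limit of > 100000 nM in this assay, at which 1 of the 3 values shown sits)
compound 3, `O=C(CCc1ccc(-c2cccc(F)c2)cc1)N1CCCC1`: 1800 nM

Among the two numbers, compound 1 stands highest; compound 3 has the lower number, and that gap lies beyond the usual scatter. For compound 2 only the limit is known, so it cannot be placed on the same scale as the other two.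

Compound 4, `CCCc1cccc(CCCCCCC(=O)N2CCCC2)c1`, is not yet measured in this assay. It differs from compound 1 in one place: propyl in place of fluoro on an aromatic carbon, the propyl entering meta to a large group on the six-membered aromatic ring of carbon only. Within the data shown here, no step between measured compounds matches this exchange, so there is no direct precedent for it. The expectation is a modest move toward a lower number, roughly of the size seen between compound 1 and compound 3, though a change no larger than the scatter, in either direction, would not be surprising. Compound 4 is estimated at 3000 nM, with a range of 800 nM to 12000 nM, which means an expected step of a 2.4-fold lower number from compound 1 to compound 4 (0.39 log units; beyond the scatter).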

Compound 4, half-maximal inhibitory concentration: > 100000 nM
Compound 4: a limit, no number (the forecaster's own chance of this, stated with the estimate: 10%); at least 33-fold (1.52 log units) between middle value and limit.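

Propyl in place of fluoro on an aromatic carbon, meta to a large group, gives an at least 13-fold higher number from compound 1 to compound 4 (1.13 log units; beyond the scatter) in this assay. Among these compounds, this is the only readable step at this position, and it shows that the position does not accept every replacement for fluoro: with the rest of the core of compound 1 unchanged, this single exchange is enough to lose a measurable value. Compound 4 gives > 100000 nM, which is a limit of the assay and not a number, so the step has a lower bound but no true size, and the limit is now a common result in this small set: the limit of > 100000 nM in this assay, at which 2 of the 4 values shown sit.

The compounds shown leave open where the loss begins, since a single exchange cannot separate the effect of the propyl chain from that of removing fluoro, and methyl or ethyl at the same place would show whether any carbon chain there retains a value near that of compound 1, which gives 7300 nM. Also open, as far as these compounds go, is whether a methoxy group or a hydroxyl group at this position, or a ring with no group there at all, would keep a number in this assay.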